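The source may report more compounds than this note shows. Statements on the series, on what has been measured and on what is new or still open speak of the compounds shown alone.

Measured so far:
Compound 1 `COc1ccccc1C(C1=C(O)C(=O)c2ccccc2C1=O)c1c[nH]c2ccccc12`: > 200000 nM (a limit of the assay, not a number)
Compound 2 `O=C1C(O)=C(C(c2ccccc2)c2c(-c3ccccc3)[nH]c3ccccc23)C(=O)c2ccccc21`: 26400 nM

Both compounds were tested in a toxicity assay (Homo sapiens) for cytotoxicity, read by MTT assay, with a stated time of 48 h (a lower number here means a stronger inhibitor, a higher number a weaker inhibitor), but only one of them gave a number. Compound 1 stands at a limit of this assay, recorded as > 200000 nM. Among the measured compounds shown here, the series so far contains (the limit of > 200000 nM in this assay, at which 1 of the 2 values shown sits), and that entry belongs to compound 1. Compound 2, by contrast, gives a measured 26400 nM.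

Compound 3 `O=C1C(O)=C(C(c2cccs2)c2c[nH]c3ccccc23)C(=O)c2ccccc21` keeps the core of compound 1 and carries thiophen-2-yl in place of 2-methoxyphenyl on a saturated chain carbon bound to an aromatic carbon and a double-bonded ring carbon. For the measured compounds named here, no pair of measured compounds isolates this change, so the expectation rests on the two results alone. With compound 2 at 26400 nM, a modest step toward a lower number is expected in this assay. Compound 3 may also remain at the limit. The expected step is an at least 1.8-fold lower number from compound 1 to compound 3 (0.25 log units; that floor lies within the scatter). For compound 3 the estimated value is 110000 nM, with an expected range from 35000 nM to 250000 nM.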

Compound 3, half-maximal inhibitory concentration: 31300 nM
Estimate against measurement, compound 3: 3.5-fold (0.55 log units) above; the whole stated range lies above it.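

In this assay, thiophen-2-yl in place of 2-methoxyphenyl on a saturated chain carbon bound to an aromatic carbon and a double-bonded ring carbon gives an at least 6.3-fold lower number from compound 1 to compound 3 (0.80 log units; beyond the scatter). Among the compounds shown here, this is the first evidence that a change at this one place, with the rest of compound 1 kept, is enough to bring a measurable number; compound 1 and compound 2 differ in more than one place and could not show that. The step is a floor and not a full size, because compound 1 stands at a limit of the assay and not at a number: the limit of > 200000 nM in this assay, at which 1 of the 3 values shown sits.

The compounds shown leave open whether the step belongs to the loss of 2-methoxyphenyl or to the arrival of the five-membered aromatic ring with its sulfur, as no compound separates the two. They also leave open how a furan-2-yl, a pyridin-2-yl or a group carrying an amine would behave on the same carbon, and so whether thiophen-2-yl is special there or one of many groups that would serve.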